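A few compounds are considered here, and "the series" means these few. Any claim that something is new, unique, unknown or untested is made for them only; others in the source may bear on it.

Compound 1 `O=c1cc(-c2ccccc2)oc2ccc(N3COc4c(cccc4[N+](=O)[O-])C3)cc12` was tested in a functional assay on MCF7 cells (Homo sapiens) for inhibition, read by MTT assay, with a stated time of 48 h, tested at 7.5 ug/mL (a lower number here means less inhibition of growth, a higher number more inhibition of growth at the concentration tested), and gives 8.2%. Compound 2 `Cc1cc(C)c2c(c1)CN(c1ccc3c(=O)cc(-c4ccccc4)oc3c1)CO2` gives 11.3% in this assay, a figure within the scatter of that of compound 1, so the two stand together at weak inhibition. Compound 3 `O=c1cc(-c2ccccc2)oc2ccc(N3COc4ccccc4C3)cc12` differs from compound 1 in one place: hydrogen in place of nitro on an aromatic carbon. Going by the values given here, no pair of measured compounds shows this change, so its size is unknown from the data. Because compound 1 gives 8.2%, compound 3 is expected to remain weak. The expected step is a number 0.8 percentage points higher from compound 1 to compound 3 (within the scatter), none beyond the scatter. Compound 3 is estimated at 9%, between 0% and 20%.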

Compound 3, percent growth inhibition at one concentration: 8.7%
Compound 3: the middle estimate sits 0.3 percentage points above what was measured; measured number inside the range.
By their numbers in this assay, from the lowest: compounds 1, 3 and 2 (each within the scatter of the next).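

In this assay, hydrogen in place of nitro on this aromatic carbon gives a number 0.5 percentage points higher from compound 1 to compound 3 (within the scatter), so the nitro group is not needed for the low reading of compound 1, and inhibition remains weak without it. Going by these compounds alone, at this place, ortho to a fused ring and meta to a fused ring, the one change tested leaves the reading unmoved beyond the scatter. No measurement here accounts for this outcome.

On these data alone, whether an amine or a carboxylic acid on this same carbon would raise the inhibition stays open. So does whether a methoxy group there would move the reading beyond the scatter.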